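This account rests on a few compounds, and the source may have more. Where it says the series, first, only, none or still open, it means among the compounds named here.

Three analogues that share a core of two benzylidene-bearing rings linked through an amide were examined in a functional assay on CCRF-CEM cells (Homo sapiens) for cytotoxicity; a higher number here means a weaker inhibitor, a lower number a stronger inhibitor. Compound 1 `Cc1cccc(C)c1NC(=O)/C=C/C(=O)N1C/C(=C\c2ccccc2)C(=O)/C(=C/c2ccccc2)C1` gives 7400 nM in this assay. Compound 3 `Cc1ccc(NC(=O)/C=C/C(=O)N2C/C(=C\c3ccccc3)C(=O)/C(=C/c3ccccc3)C2)cc1C` gives 7100 nM. The two differ only in 2,6-dimethylphenyl in place of 3,4-dimethylphenyl on an amide-type nitrogen, and the change produced a 1.0-fold higher number from compound 3 to compound 1 (0.02 log units; within the scatter). Compound 2 `Cc1ccc(NC(=O)/C=C/C(=O)N2C/C(=C\c3ccc([N+](=O)[O-])cc3)C(=O)/C(=C/c3ccc([N+](=O)[O-])cc3)C2)cc1C` gives 700 nM, the lowest of the three numbers, and stands beyond the scatter from both others; how its core differs from that of compound 3 is not broken down here.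

Compound 4 `Cc1cccc(C)c1NC(=O)/C=C/C(=O)N1C/C(=C\c2ccc([N+](=O)[O-])cc2)C(=O)/C(=C/c2ccc([N+](=O)[O-])cc2)C1`, not yet measured, relates to compound 2 exactly as compound 1 relates to compound 3: the difference is 2,6-dimethylphenyl in place of 3,4-dimethylphenyl on an amide-type nitrogen, at a place described in the same words in both pairs, so it is the same change. Because the same change gave a 1.0-fold higher number from compound 3 to compound 1 (0.02 log units; within the scatter), the step is expected to be small, around no change at the digits printed from compound 2 to compound 4 (within the scatter). Among the measured compounds shown here, compound 4 is therefore estimated at 700 nM in this assay, most likely between 350 nM and 1400 nM, resting on the single measured precedent and on the value of compound 2.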

Compound 4, half-maximal inhibitory concentration: 230 nM
Estimate against measurement, compound 4: 3.0-fold (0.48 log units) above, and the stated range ends above it.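

In this assay, putting 2,6-dimethylphenyl in place of 3,4-dimethylphenyl on the amide-type nitrogen gave a 3.0-fold lower number from compound 2 to compound 4 (0.48 log units; beyond the scatter), and setting this beside the earlier pair shows that the change did not carry over unchanged between the two cores: the same change on two cores in this assay, a 1.0-fold higher number (0.02 log units; within the scatter) from compound 3 to compound 1 and a 3.0-fold lower number (0.48 log units; beyond the scatter) from compound 2 to compound 4, 3.2-fold (0.50 log units) apart, beyond the scatter of two such steps

In this series, then, the effect of the change depends on the core it sits on, at least for these two pairs, and a step read on one core was not a safe guide to the other. The two pairs do not show why the steps differ or which feature of the core matters, and they give no rule for any further core.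

The compounds shown leave open how the same change would read on a core carrying an amine, a methoxy group or a chlorine in place of the nitro groups of compound 2 and compound 4. They also leave open whether a single methyl group on the phenyl ring would give a step like either of these two.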